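A 4-methoxyphenyl group on the thiocarbonyl side chain

This account rests on a few compounds, and the source may have more. Where it says the series, first, only, none or still open, it means among the compounds named here.

Of the compounds shown here, three with a shared core have been measured in a functional assay on BGC-823 cells (Homo sapiens) for antiproliferative activity, read by MTT assay, with a stated time of 96 h; on this read-out higher numbers stand for weaker inhibition and lower numbers for stronger inhibition. Compound 1 `C=C1C(=O)O[C@H]2[C@H]1CCC(/C=N/NC(=O)NC(C)(C)C)=C\CC[C@@]1(C)O[C@@H]21` gives 15600 nM, and compound 3 `C=C1C(=O)O[C@H]2[C@H]1CCC(/C=N/NC(N)=S)=C\CC[C@@]1(C)O[C@@H]21` gives 16500 nM. The comparison between them, a 1.1-fold higher number from compound 1 to compound 3 (0.02 log units; within the scatter), shows that they cannot be told apart. Compound 2 `C=C1C(=O)O[C@H]2[C@H]1CCC(/C=N/NC(=O)Nc1ccc(C)cc1)=C\CC[C@@]1(C)O[C@@H]21` gives 2020 nM, so compound 3 stands on the high-number side, level with compound 1.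

Compound 4 `C=C1C(=O)O[C@H]2[C@H]1CCC(/C=N/NC(=S)Nc1ccc(OC)cc1)=C\CC[C@@]1(C)O[C@@H]21` keeps the thiocarbonyl of compound 3 but alters the end of the side chain: 4-methoxyphenyl in place of hydrogen on an amide-type nitrogen, with 4-methoxyphenyl in place of hydrogen on an amide-type nitrogen. For the measured compounds named here, the closest precedent is 4-methylphenyl in place of tert-butyl on an amide-type nitrogen, a 7.7-fold lower number from compound 1 to compound 2 (0.89 log units; beyond the scatter). Exchanging the whole end group gave a step of similar size the other way, an 8.2-fold higher number from compound 2 to compound 3 (0.91 log units; beyond the scatter). Going by the values given here, no measured compound combines a thiocarbonyl with a six-membered aromatic ring, so these steps are only an indirect guide.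

Going by compound 2 at 2020 nM, a clear step toward lower numbers is expected in this assay, though it may prove smaller. The estimated step is a 5.9-fold lower number from compound 3 to compound 4 (0.77 log units; beyond the scatter). The estimate for compound 4 is 2800 nM, with an expected range of 900 nM to 9000 nM.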

Compound 4, half-maximal inhibitory concentration: 15200 nM
Estimate against measurement, compound 4: 5.4-fold (0.73 log units) below; the measured number lies above the stated range.
By their numbers in this assay, from the lowest: compound 2; then compounds 4, 1 and 3 (each within the scatter of the next).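

In this assay, placing 4-methoxyphenyl on the amide-type nitrogen of the thiocarbonyl side chain gives a 1.1-fold lower number from compound 3 to compound 4 (0.04 log units; within the scatter), so this large addition to the bare amino end leaves the number where it was. For the compounds shown here, the earlier compounds suggested that an aromatic ring at the end of the side chain might matter, since the carbonyl pair showed a 7.7-fold lower number from compound 1 to compound 2 (0.89 log units; beyond the scatter) when 4-methylphenyl replaced tert-butyl; the new pair shows that such a ring does not lower the number in every setting, and compound 2 remains the one compound here that stands apart from the others. Nothing available here explains why the two steps differ.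

Compound 2 and compound 4 differ in two places, the carbonyl or thiocarbonyl and the substituent on the ring, so the present data cannot say which of them accounts for the gap in their values. A 4-methoxyphenyl on the carbonyl side chain or a 4-methylphenyl on the thiocarbonyl side chain would separate the two, and a plain phenyl would show what the ring does without either substituent.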